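Ester branching in a small series: working notes

The source may report more compounds than this note shows. Statements on the series, on what has been measured and on what is new or still open speak of the compounds shown alone.

Measured compounds in an assay on membranes from HEK293 cells for displacement of a labelled ligand from adenosine receptor A2b (Homo sapiens), read by scintillation counting, with a stated time of 30 min, tested at 1 uM; a higher number here means more inhibition at the concentration tested (going by the name of the read-out), a lower number less inhibition:

compound 1, `CC1=C(C(=O)OCC(C)C)C(c2ccco2)NC(=S)N1`, gives 18%
compound 2, `CC1=C(C(=O)OC(C)(C)C)C(c2ccco2)NC(=S)N1`, gives 9%
compound 3, `CC1=C(C(=O)OCC(C)C)C(c2ccco2)NC(=O)N1C`, gives 4%

Compound 2 differs from compound 1 by tert-butyl in place of isobutyl on an oxygen next to a carbonyl group. The step was a number 9 percentage points lower from compound 1 to compound 2 (within the scatter). The difference between the core of compound 1 and the core of compound 3 is not broken down here; compound 3 sits lowest of the three in this assay.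

Compound 4, `CC1=C(C(=O)OC(C)(C)C)C(c2ccco2)NC(=O)N1C`, is not yet measured. It differs from compound 3 by tert-butyl in place of isobutyl on an oxygen next to a carbonyl group, the same change as between compound 1 and compound 2, at the same place.

For compound 4 a step of a number 2 percentage points lower from compound 3 to compound 4 (within the scatter) is expected, resting on the earlier step of a number 9 percentage points lower from compound 1 to compound 2 (within the scatter) and on the low starting point of compound 3, which leaves little room for a further drop. Compound 4 is estimated at 2%, with a range from -8% to 13%.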

Compound 4, a percentage reported as inhibition, at one concentration (the size of the read-out at that concentration, not a potency): 26%
Compound 4: middle estimate off by 24 percentage points, on the low side; the measured number lies above the stated range.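

In this assay, tert-butyl in place of isobutyl on the core of compound 3 gave a number 22 percentage points higher from compound 3 to compound 4 (beyond the scatter). The change does not carry over as a constant step between the two cores: the same change on two cores in this assay, a number 9 percentage points lower (within the scatter) from compound 1 to compound 2 and a number 22 percentage points higher (beyond the scatter) from compound 3 to compound 4, 31 percentage points apart, beyond the scatter of two such steps. This shows that the outcome of the change depends on the core in these two pairs, but it does not show which difference between the cores is responsible, and it rests on readings at a single concentration rather than on potencies.

On these data alone, it remains open how either core responds to other groups on the same oxygen, such as ethyl or a longer chain. Replacing the ester with a carboxylic acid or an amide is equally untested in the compounds shown.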